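The source may report more compounds than this note shows. Statements on the series, on what has been measured and on what is new or still open speak of the compounds shown alone.

Working notes on the series. Compound 1 `CC1=C(C(=O)OC(C)(C)C)C(c2ccoc2)NC(=O)N1` gives 11% in an assay on membranes from CHO cells for displacement of a labelled ligand from adenosine receptor A1 (Homo sapiens), read by scintillation counting, with a stated time of 60 min, tested at 1 uM; a higher number here means more inhibition at the concentration tested (going by the name of the read-out), a lower number less inhibition. Compound 2 `CC1=C(C(=O)OCc2ccccc2)C(c2ccoc2)NC(=O)N1` gives 41% in this assay. The change between them, (benzyl in place of tert-butyl on an oxygen next to a carbonyl group), produced the step of a number 30 percentage points higher from compound 1 to compound 2 (beyond the scatter). Compound 3 `CC1=C(C(=O)OC(C)(C)C)C(c2ccco2)NC(=S)N1` gives 3% in this assay; the difference between the core of compound 3 and the core of compound 1 is not broken down here. Against compound 1 the number of compound 3 lies within the scatter, against compound 2 it lies beyond it.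

Compound 4 `CC1=C(C(=O)OCc2ccccc2)C(c2ccco2)NC(=S)N1` is not yet measured. Its change from compound 3, (benzyl in place of tert-butyl on an oxygen next to a carbonyl group), is the same change as that from compound 1 to compound 2, and among the compounds shown it occurs two times in all, once measured and once pending.

Within the data shown here, the step from compound 3 to compound 4 is expected to be a number 25 percentage points higher from compound 3 to compound 4 (beyond the scatter), set beside the measured a number 30 percentage points higher from compound 1 to compound 2 (beyond the scatter), because the one measured instance of this change gave a number 30 percentage points higher from compound 1 to compound 2 (beyond the scatter); the differing cores leave the transfer uncertain, as no second instance exists. Compound 4 is therefore estimated at 28%, with the expected range 8% to 50%.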

Compound 4, a percentage reported as inhibition, at one concentration (the size of the read-out at that concentration, not a potency): 32%
For compound 4 the middle estimate is 4 percentage points below the measured one; the measured number falls inside the stated range.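

In this assay, benzyl in place of tert-butyl on an oxygen next to a carbonyl group gave a number 29 percentage points higher from compound 3 to compound 4 (beyond the scatter). Set beside the earlier instance, the change carried over between the two cores with no distinguishable difference in size: the same change on two cores in this assay, a number 30 percentage points higher (beyond the scatter) from compound 1 to compound 2 and a number 29 percentage points higher (beyond the scatter) from compound 3 to compound 4, 1 percentage points apart, within the scatter of two such steps. This agreement rests on two cores and a single test concentration, so it does not show that the step would hold on any further core, what causes it, or how large a change in potency it reflects.

The compounds shown leave open how the step would behave if the differences between the core of compound 1 and the core of compound 3 were taken one at a time. Also open, as far as these compounds go, is what other groups on the same oxygen would give, such as a longer chain, or a benzyl carrying an amine or a carboxylic acid, since only tert-butyl and benzyl appear there.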